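This account rests on a few compounds, and the source may have more. Where it says the series, first, only, none or still open, it means among the compounds named here.

Compound 1, `Nc1nc2c(c(-c3ccccc3)cn2[C@@H]2O[C@H](CO)[C@@H](O)[C@H]2O)c(=O)[nH]1`, in a functional assay on K562 cells (Homo sapiens), read by MTT assay, with a stated time of 72 h; on this read-out lower numbers stand for stronger inhibition and higher numbers for weaker inhibition: > 20000 nM, a limit of the assay rather than a number.
Compound 2, `O=c1[nH]cnc2c1c(-c1cccs1)cn2[C@@H]1O[C@H](CO)[C@@H](O)[C@H]1O`, in this assay: > 20000 nM, likewise a limit.
Compound 3, `Cc1nc(N)c2c(-c3ccccc3)cn([C@@H]3O[C@H](CO)[C@@H](O)[C@H]3O)c2n1`, in this assay: > 20000 nM, again a limit.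

Compound 2 therefore stands at the edge of what this assay can report, and it does not stand alone there: the limit of > 20000 nM in this assay, at which 3 of the 3 values shown sit. No pair among these three compounds differs in a single place, so no measured step is available to calibrate the change that leads to compound 4, `O=c1[nH]cnc2c1c(-c1ccccc1)cn2[C@@H]1O[C@H](CO)[C@@H](O)[C@H]1O`. That change is phenyl in place of thiophen-2-yl on an aromatic carbon. Compound 1 and compound 3 both carry a phenyl on the same kind of position, and both sit at the limit, so the phenyl by itself has given no sign of inhibition in this series. In this assay the step from compound 2 to compound 4 is expected to be none beyond the scatter, with a step that the limit leaves unreadable from compound 2 to compound 4 as the estimate of that step. Compound 4 is accordingly expected to come out at 30000 nM, within 10000 nM to 100000 nM, most probably reported as a limit once more.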

Compound 4, half-maximal inhibitory concentration: > 20000 nM
Compound 4: no number, only a limit; the forecaster's own chance of this, stated with the estimate: 85%; the middle value is on the limit's open side.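

Compound 4 also comes out as a limit in this assay, so neither its step from compound 2 nor its step from compound 1 can be read: the limit of > 20000 nM in this assay, at which 4 of the 4 values shown sit. The compounds shown leave open whether any change on the shared core gives a measurable value in this assay, and how phenyl and thiophen-2-yl compare there.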